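Thiophene sulfonamide series: aryl ether replacement for benzyl ether

The source may hold more compounds than are shown below. What is called first, only, known or untested is meant among the compounds shown, and "the series" means these compounds.

Measured so far:
compound 1 `Cc1ccc(-c2ccsc2S(=O)(=O)NCCNC(=S)Nc2ccc([N+](=O)[O-])cc2)c(Oc2ccc(O)c(O)c2)c1` — 5100 nM
compound 2 `O=C(NCCNS(=O)(=O)c1ccc(-c2ccccc2OCc2ccccc2)s1)Nc1cc(C(F)(F)F)cc(C(F)(F)F)c1` — > 50000 nM
compound 3 `O=S(=O)(NCCNC(=S)Nc1cc(C(F)(F)F)cc(C(F)(F)F)c1)c1ccc(-c2ccccc2OCc2cccc(O)c2)s1` — 12000 nM

In a functional assay on RS4-11 cells (Homo sapiens) for inhibition, read by CCK-8 assay, with a stated time of 48 h (on this read-out lower numbers stand for stronger inhibition and higher numbers for weaker inhibition), compound 2 gives only a limit, > 50000 nM, so it has no number of its own here (the limit of > 50000 nM in this assay, at which 1 of the 3 values shown sits). In this assay compound 1 gives 5100 nM, and compound 3 gives 12000 nM.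

Compound 4 `Nc1ccc(Oc2ccccc2-c2ccc(S(=O)(=O)NCCNC(=O)Nc3cc(C(F)(F)F)cc(C(F)(F)F)c3)s2)cc1` is the next one. It differs from compound 2 by 4-aminophenyl in place of benzyl on an oxygen on an aromatic ring. Going by the values given here, no step between two measured compounds is available to set the size of this change. Since the starting point is a limit, compound 4 is expected to come back with a number rather than a limit, but only a modest one. The estimated step of an at least 2.5-fold lower number from compound 2 to compound 4 (0.39 log units; beyond the scatter) rests on a starting limit, so its size is uncertain. In this assay compound 4 is expected to give 20000 nM, with a range from 5000 nM to 60000 nM.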

Compound 4, half-maximal inhibitory concentration: 11900 nM
The estimate for compound 4 lay 1.7-fold (0.23 log units) above the measured number, and the stated range covers the measured number.
By their numbers in this assay, from the lowest: compound 1; then compounds 4 and 3 (each within the scatter of the next). At a limit, above all of these: compound 2.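

In this assay, 4-aminophenyl in place of benzyl on an oxygen on an aromatic ring gives an at least 4.2-fold lower number from compound 2 to compound 4 (0.62 log units; beyond the scatter), so the read-out responds to this position on an otherwise unchanged core. The true size of the step stays unknown because its starting point is only a limit: the limit of > 50000 nM in this assay, at which 1 of the 4 values shown sits.

The compounds shown do not separate the amine from the change of benzyl to an aryl ether. Plain phenyl, or a carboxylic acid in place of the amine, on the same oxygen would address that.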